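Replacing a Phenolic Hydroxy by Dimethylamino

A few compounds are considered here, and "the series" means these few. Any claim that something is new, unique, unknown or untested is made for them only; others in the source may bear on it.

Of the compounds shown here, two on a shared core have been measured in a physicochemical assay for lipophilicity; on this read-out higher numbers stand for higher lipophilicity and lower numbers for lower lipophilicity. Compound 1 `CC1(C)N([O])C(c2ccc(O)cc2)=[N+]([O-])C1(C)C` gives 0.619 in this assay, which is the lowest of the two numbers, with compound 2 as its nearest neighbour. Compound 2 `COc1cc(C2=[N+]([O-])C(C)(C)C(C)(C)N2[O])ccc1O` gives 1.14 in this assay. Going by the values given here, the single measured step, a number 0.52 log units higher from compound 1 to compound 2 (beyond the scatter), is the only guide to how this core responds to a change on the aromatic ring. Compound 3 `CN(C)c1ccc(C2=[N+]([O-])C(C)(C)C(C)(C)N2[O])cc1` has not yet been measured in this assay. It differs from compound 1 as follows: dimethylamino in place of hydroxy on an aromatic carbon. Among the compounds with values here, no measured step covers this particular exchange, so the one step from compound 1 to compound 2 bears on it only as a sign that the aromatic substituent moves the read-out by a modest, detectable amount. A rise beyond the scatter is expected, as dimethylamino in place of hydroxy usually adds lipophilicity. For compound 3 the estimated value is 1.45, with a range from 1.05 to 1.85. The expected step is therefore a number 0.83 log units higher from compound 1 to compound 3 (beyond the scatter).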

Compound 3, partition coefficient: 2.02
Compound 3: the middle estimate sits 0.57 log units below what was measured; the measured number lies above the stated range.
By their numbers in this assay, from the lowest: compound 1; then compound 2; then compound 3.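

In this assay the exchange of hydroxy for dimethylamino on an aromatic carbon, para to a large group, gives a number 1.40 log units higher from compound 1 to compound 3 (beyond the scatter). This step is large, whereas the earlier step, a number 0.52 log units higher from compound 1 to compound 2 (beyond the scatter), was modest and left the hydroxy in place, so the hydroxy site itself can carry the read-out much further on this core than that first change suggested. Hydroxy counts 1 hydrogen-bond donor and dimethylamino 0, and dimethylamino brings 3 heavy atoms where hydroxy has 1, but the data do not separate these differences and offer no measured explanation for the size of the step.

On these data alone, whether a plain amino group or methoxy on this same carbon would give a step of similar size remains open. So does whether a carboxylic acid here would move the number in the opposite direction.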